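Lengthening a phenoxy-linked chain and cytotoxicity

The compounds below may be only part of what the source reports. "The series", "measured", "known", "first", "only" and "open" are said of these compounds alone.

For the measured compounds named here, compound 2 `CC(C)NC(=N)c1ccc2cc(-c3cccc(OCCCCCOc4ccccc4)c3)oc2c1` was tested in an ADME assay on L6 cells (Rattus norvegicus) for cytotoxicity, read by resazurin assay, with a stated time of 70 h (on this read-out lower numbers stand for stronger inhibition and higher numbers for weaker inhibition), where compound 2 gives 20100 nM, the lower of the two numbers measured so far; compound 1 `CC(C)NC(=N)c1ccc2cc(-c3cccc(OCCCOc4ccccc4)c3)oc2c1`, which carries a shorter chain, gives 82300 nM in this assay. Compound 3 `CC(C)NC(=N)c1ccc2cc(-c3cccc(OCCCCCCOc4ccccc4)c3)oc2c1` extends the chain by one more link: phenoxymethyl in place of phenoxy on a saturated chain carbon, five bonds along the chain from an oxygen on an aromatic ring. Going by the values given here, the only measured step that bears on this, a 4.1-fold lower number from compound 1 to compound 2 (0.61 log units; beyond the scatter), also lengthened the chain, and the number fell. A smaller step in the same direction is therefore expected here, a 1.7-fold lower number from compound 2 to compound 3 (0.22 log units; within the scatter). Compound 3 is estimated to give about 12000 nM, within a range from 5000 nM to 30000 nM.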

Compound 3, half-maximal inhibitory concentration: 10100 nM
Estimate against measurement, compound 3: 1.2-fold (0.07 log units) above; measured number inside the range.
By their numbers in this assay, from the lowest: compounds 3 and 2 (each within the scatter of the next); then compound 1.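

In this assay the extra chain link gives a 2.0-fold lower number from compound 2 to compound 3 (0.30 log units; within the scatter) so this lengthening, unlike the earlier one, cannot be told apart from repeat-measurement variation. Taken across the whole range of chains shown, the change still gives an 8.1-fold lower number from compound 1 to compound 3 (0.91 log units; beyond the scatter) so the longest chain stands clearly apart from the shortest. Nothing available here explains how chain length connects to these numbers.

As far as these compounds go, whether a still longer chain would leave the number level or shift it remains open. So does the effect of a carboxylic acid in place of the phenoxy group.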